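The compounds below may be only part of what the source reports. "The series", "measured", "known", "first", "only" and "open" are said of these compounds alone.

The measured compounds:
Compound 1 `COc1cc(OC)cc(-c2ccc(-n3cc(-c4cccc(C(=O)O)c4)nn3)cc2)c1` gives 92% in an ADME assay on microsomes from liver (Mus musculus) for metabolic stability, with a stated time of 1 h; a lower number here means that less of the compound is left, a higher number that more of the compound is left.
Compound 2 `O=C(O)c1cccc(-c2cn(-c3ccc(-c4ccc5c(c4)OCCO5)cc3)nn2)c1` gives 94% in this assay.
Compound 3 `COc1ccc(F)c(-c2ccc(-n3cc(-c4cccc(C(=O)O)c4)nn3)cc2)c1` gives 93% in this assay.

Compound 1 gives the smallest of these three numbers, but it is not set apart from the others: the step of a number 1 percentage points higher from compound 1 to compound 3 (within the scatter) and the step of a number 2 percentage points higher from compound 1 to compound 2 (within the scatter) both lie within the scatter, and the same holds for the step of a number 1 percentage points lower from compound 2 to compound 3 (within the scatter). All three compounds share one core and differ only in the aryl group attached to it, and every exchange of that aryl group seen so far has left the read-out essentially where it was.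

Compound 4 `COc1cccc(-c2ccc(-n3cc(-c4cccc(C(=O)O)c4)nn3)cc2)c1` has not yet been measured in this assay. It differs from compound 1 in one place: hydrogen in place of methoxy on an aromatic carbon. Among the measured compounds shown here, no measured step removes a single methoxy group while keeping the rest of the aryl group; the closest comparisons are a number 2 percentage points higher from compound 1 to compound 2 (within the scatter) and a number 1 percentage points higher from compound 1 to compound 3 (within the scatter), in which the whole 3,5-dimethoxyphenyl group is replaced by a different aryl group, and neither produced a change beyond the scatter. Compound 4 is therefore expected to show a number 1 percentage points lower from compound 1 to compound 4 (within the scatter), a step that stays within the scatter. For compound 4 the estimated value is 91%, with a range from 80% to 98%.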

Compound 4, percent of the compound remaining in the Mus musculus assay: 91%
Beside the measured number, compound 4's estimate shows no gap at the digits printed, and the stated range covers the measured number.
By their numbers in the Mus musculus assay, from the lowest: compounds 4, 1, 3 and 2 (each within the scatter of the next).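

Taking one methoxy group off the 3,5-dimethoxyphenyl group leaves the read-out in the Mus musculus assay where it stood, with a number 1 percentage points lower from compound 1 to compound 4 (within the scatter), and the comparisons with the other aryl groups agree, with a number 2 percentage points lower from compound 3 to compound 4 (within the scatter) and a number 3 percentage points lower from compound 2 to compound 4 (within the scatter). The same change does register elsewhere: in a physicochemical assay for solubility, measured as thermodynamic solubility (a lower number here means a less soluble compound, a higher number a more soluble compound), compound 1 gives 18.7 ug/mL and compound 4 gives 856 ug/mL. This position, quiet in every step seen so far, therefore carries the first large step, and hydrogen in place of methoxy raises solubility while the share of compound left stays within the scatter: the measured solubility of compound 1, 18.7 ug/mL, and of compound 4, 856 ug/mL, a 46-fold higher number (1.66 log units; beyond the scatter)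

Going by these compounds, whether this solubility step would hold on the other aryl groups stays open, since it rests on a single pair of compounds. Also open, on these data alone, is how an amine, a hydroxyl group or a longer chain such as ethoxy in that place would read in the Mus musculus assay and in the physicochemical assay.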